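A few compounds are considered here, and "the series" means these few. Any claim that something is new, unique, unknown or untested is made for them only; others in the source may bear on it.

Measured so far:
- compound 1 `O=S(=O)(NCCNCc1cccc2ccccc12)c1cc(C(F)(F)F)cc(C(F)(F)F)c1` gives 22000 nM
- compound 2 `O=S(=O)(NCCCNCc1ccc(Cl)c(C(F)(F)F)c1)c1cc(C(F)(F)F)cc(C(F)(F)F)c1` gives 9600 nM
- compound 3 `CN(CCCNS(=O)(=O)c1cc(C(F)(F)F)cc(C(F)(F)F)c1)Cc1ccccc1` gives 51000 nM

All three numbers come from a functional assay on ASPC1 cells (Homo sapiens) for inhibition, read by MTT assay, with a stated time of 72 h; a lower number here means a stronger inhibitor of growth, a higher number a weaker inhibitor of growth. Among them compound 1 stands second highest: compound 2 gives a number that is lower by more than the usual scatter, and compound 3 gives a number that is higher by more than the usual scatter. None of these three compounds differs from another in only one place, so no single-change step can be read from the measured set; only the bare values can be compared.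

Compound 4 `CC(C)(C)c1ccc(CNCCNS(=O)(=O)c2cc(C(F)(F)F)cc(C(F)(F)F)c2)cc1` is the one still to be measured. It differs from compound 1 by 4-(tert-butyl)phenyl in place of naphthalen-1-yl on a saturated chain carbon bound to an amine nitrogen. The change keeps the same count of heavy atoms and the same core, and nothing in the measured set isolates what such a swap does. The step of a 1.4-fold lower number from compound 1 to compound 4 (0.14 log units; within the scatter) is therefore expected to be small, no further than the usual scatter in either direction. On that basis compound 4 is estimated at about 16000 nM, with a range from 5000 nM to 50000 nM.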

Compound 4, concentration for 50% growth inhibition: 14000 nM
Compound 4: the middle estimate sits 1.1-fold (0.06 log units) above what was measured; the range from low to high includes it.
By their numbers in this assay, from the lowest: compounds 2, 4 and 1 (each within the scatter of the next, the first and the last beyond it); then compound 3.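

In this assay, going by these compounds alone, putting 4-(tert-butyl)phenyl in place of naphthalen-1-yl on a saturated chain carbon bound to an amine nitrogen gives a 1.6-fold lower number from compound 1 to compound 4 (0.20 log units; within the scatter), the only single-change step these compounds offer. It shows that, in this one pair, a group with two six-membered aromatic rings and a group with one such ring plus a tert-butyl, each of 10 carbon atoms, cannot be told apart by this read-out. No measurement shown here explains why the two groups read alike.

From the compounds shown here alone, whether this position would also tolerate a ring containing nitrogen, such as pyridine, or a group carrying a carboxylic acid, remains open. So does whether the same swap would read alike on the other chains seen in compound 2 and compound 3.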